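The source may report more compounds than this note shows. Statements on the series, on what has been measured and on what is new or still open speak of the compounds shown alone.

Measured so far in an assay on cells for inhibition of Ectonucleotide pyrophosphatase/phosphodiesterase family member 1 (Homo sapiens), with a stated time of 60 min, tested at 1 uM; a higher number here means more inhibition at the concentration tested (going by the name of the read-out), a lower number less inhibition:
- compound 3 `COc1cccc(/C=C/c2nc(N3CCC(CCNS(N)(=O)=O)CC3)c3cc(OC)c(OC)cc3n2)c1` — in this assay compound 3 gives 88%
- compound 1 `COc1cc2nc(/C=C/c3ccccc3F)nc(N3CCC(CCNS(N)(=O)=O)CC3)c2cc1OC` — in this assay compound 1 gives 78%
- compound 2 `COc1cc2nc(/C=C/c3cccc(F)c3)nc(N3CCC(CCNS(N)(=O)=O)CC3)c2cc1OC` — in this assay compound 2 gives 14%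

Compound 3 carries the highest number of the three; compound 1 sits within the scatter of it a number 10 percentage points higher from compound 1 to compound 3 (within the scatter), while compound 2 lies well beneath it a number 74 percentage points higher from compound 2 to compound 3 (beyond the scatter).

Compound 4 `COc1ccc(/C=C/c2nc(N3CCC(CCNS(N)(=O)=O)CC3)c3cc(OC)c(OC)cc3n2)cc1` is still to be tested. It differs from compound 3 by 4-methoxyphenyl in place of 3-methoxyphenyl on a double-bonded chain carbon bound to a double-bonded chain carbon.

Going by the values given here, no measured step moves a methoxy group from one ring position to another. The nearest guidance is the large shift when a fluoro substituent changed ring position, a number 64 percentage points lower from compound 1 to compound 2 (beyond the scatter), and the large swap a number 74 percentage points higher from compound 2 to compound 3 (beyond the scatter): position on this ring evidently matters, yet these three compounds do not tell which direction a methoxy move will take. The working expectation for compound 4 is therefore a loss, a number 33 percentage points lower from compound 3 to compound 4 (beyond the scatter), with wide uncertainty. Compound 4 is estimated at 55%, in the range 15% to 92%.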

Compound 4, a percentage reported as inhibition, at one concentration (the size of the read-out at that concentration, not a potency): 66%
Compound 4: the middle estimate sits 11 percentage points below what was measured; the measured number falls inside the stated range.
By their numbers in this assay, from the lowest: compound 2; then compound 4; then compounds 1 and 3 (each within the scatter of the next).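

In this assay, the methoxy group also responds to its place on the ring: going from 3-methoxyphenyl to 4-methoxyphenyl gives a number 22 percentage points lower from compound 3 to compound 4 (beyond the scatter), a modest step beside the large fluoro move, a number 64 percentage points lower from compound 1 to compound 2 (beyond the scatter). The 4-methoxyphenyl group still retains much of the inhibition, with a number 52 percentage points higher from compound 2 to compound 4 (beyond the scatter), though it does not match the 2-fluorophenyl group, with a number 12 percentage points lower from compound 1 to compound 4 (beyond the scatter).

Going by these compounds, how a 2-methoxyphenyl group, or an amine or carboxylic acid on this ring, would behave remains open. Nothing available explains the dependence on ring position.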